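Trifluoromethoxy for Ethyl in a Fatty Acid Transport Series

A few compounds are considered here, and "the series" means these few. Any claim that something is new, unique, unknown or untested is made for them only; others in the source may bear on it.

Compound 1 `CCc1ccc2oc(CSc3nnc(CNc4ccccc4)n3CC)nc2c1` belongs to a set of three analogues built on the same core. In an assay on isolated protein for inhibition of long-chain fatty acid transport protein 1 (Homo sapiens) (on this read-out higher numbers stand for weaker inhibition and lower numbers for stronger inhibition), compound 1 gives only a limit of the assay, > 1000 nM. Compound 2 `CCn1c(CNc2ccccc2)nnc1SCC(=O)Nc1ccccc1` likewise returns a limit in this assay, > 1000 nM. Compound 3 `CCn1c(CNc2ccccc2)nnc1SCC(=O)Nc1ccc(C(=O)OC(C)(C)C)cc1` also stands at a limit, > 1000 nM. Among the measured compounds shown here, because the limit of > 1000 nM in this assay, at which 3 of the 3 values shown sit, holds every value, the single measured step that the two limits leave unreadable from compound 2 to compound 3 cannot be read. Compound 4 `CCn1c(CNc2ccccc2)nnc1SCc1nc2cc(OC(F)(F)F)ccc2o1` differs from compound 1 by trifluoromethoxy in place of ethyl on an aromatic carbon. For the measured compounds named here, no measured step bears on this change, so the three limits alone inform any expectation, and no movement beyond the scatter can be foreseen. Compound 4 is therefore expected to give 3000 nM, between 700 nM and 20000 nM. The expected step that the limit leaves unreadable from compound 1 to compound 4 is of no readable size.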

Compound 4, half-maximal inhibitory concentration: 100 nM
The estimate for compound 4 lay 30-fold (1.48 log units) above the measured number; measured number below the stated range.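

In this assay, among the compounds shown here, trifluoromethoxy on this aromatic carbon gives an at least 10-fold lower number from compound 1 to compound 4 (1.00 log units; beyond the scatter), the only readable step in the set. It shows that a change at this one place on the core of compound 1 can bring a number clear of the limit. The earlier steps cannot be read, because the earlier compounds all sat at that limit: the limit of > 1000 nM in this assay, at which 3 of the 4 values shown sit.

As far as these compounds go, whether a methoxy group, a chlorine atom or an amine on this same carbon would do the same remains open. From the compounds shown here alone, the full size of the step also remains open, since its starting point is only a limit.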